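The source may hold more compounds than are shown below. What is called first, only, known or untested is meant among the compounds shown, and "the series" means these compounds.

Measured in an ADME assay on microsomes from liver (Mus musculus) for metabolic stability, with a stated time of 10 min, tested at 0.5 uM; a higher number here means that more of the compound is left, a lower number that less of the compound is left:
compound 1 `CCc1noc(C)c1[C@@H]1C[C@@](C)(c2ccc(F)cc2F)N=C(N)S1`: 41%
compound 2 `Cc1nocc1[C@@H]1C[C@@](C)(c2ccc(F)cc2F)N=C(N)S1`: 80%

Of these two, compound 2 stands highest, at 80%. The next compound is compound 3 `C[C@@]1(c2ccc(F)cc2F)C[C@@H](c2cncnc2)SC(N)=N1`, with pyrimidin-5-yl in place of 3-methyl-1,2-oxazol-4-yl on a saturated ring carbon, next to the ring sulfur: pyrimidin-5-yl in place of 3-methyl-1,2-oxazol-4-yl on a saturated ring carbon. Within the data shown here, one measured step bears on this change, a number 39 percentage points higher from compound 1 to compound 2 (beyond the scatter). It is large and concerns a group at the same place, so a swap there can matter. Among the measured compounds shown here, that step exchanged one 1,2-oxazole group for another, however, and no measured compound carries pyrimidin-5-yl. Compound 2 at 80% leaves limited room upward, so a modest step is expected, more likely down than up. The estimated change is a number 8 percentage points lower from compound 2 to compound 3 (within the scatter). For compound 3 the expected value is 72%, within a range from 50% to 90%.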

Compound 3, percent of the compound remaining: 68%
The estimate for compound 3 lay 4 percentage points above the measured number; the range from low to high includes it.
By their numbers in this assay, from the lowest: compound 1; then compound 3; then compound 2.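

In this assay, the position on the saturated ring carbon, next to the ring sulfur, now also holds a six-membered aromatic ring, and pyrimidin-5-yl in place of 3-methyl-1,2-oxazol-4-yl gives a number 12 percentage points lower from compound 2 to compound 3 (beyond the scatter). In place of 3-ethyl-5-methyl-1,2-oxazol-4-yl, the same group gives a number 27 percentage points higher from compound 1 to compound 3 (beyond the scatter), so pyrimidin-5-yl falls between the two 1,2-oxazole groups and ring size alone does not sort these three compounds. Nothing available explains why the three groups differ.

Still open, on these data alone, is where a plain phenyl or a pyridin-3-yl group would fall at this position, and whether a methyl or an amine on the pyrimidine ring would move the number. As far as these compounds go, whether the same order would hold on a different core also remains unknown.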